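A Triazole Substituent Swap at the Adenosine Receptor

The compounds below may be only part of what the source reports. "The series", "measured", "known", "first", "only" and "open" are said of these compounds alone.

Compound 1 `CNC(=O)[C@@]12C[C@@H]1[C@@H](n1cnc3c(NCc4cccc(Cl)c4)nc(C#CCCCCc4cn(-c5ccc(N)cc5)nn4)nc31)[C@H](O)[C@@H]2O`: 3%
Compound 2 `C#CCCCC#Cc1nc(NCc2cccc(Cl)c2)c2ncn([C@@H]3[C@H](O)[C@H](O)[C@]4(C(=O)NC)C[C@H]34)c2n1`: 36%

Among the compounds with values here, in an assay on CHO cells for displacement of a labelled ligand from adenosine receptor A1 (Homo sapiens), read by scintillation counting, tested at 10 uM (on this read-out lower numbers stand for less inhibition and higher numbers for more inhibition at the one concentration tested (going by the name of the read-out)), compound 1 gives 3%, the lowest of the two numbers known, while compound 2 gives 36%, a number that lies beyond the scatter above compound 1. Within the data shown here, no single structural step between these two compounds is described, so only their two values can be set side by side.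

Compound 3 `CNC(=O)[C@@]12C[C@@H]1[C@@H](n1cnc3c(NCc4cccc(Cl)c4)nc(C#CCCCCc4cn(-c5cccc([N+](=O)[O-])c5)nn4)nc31)[C@H](O)[C@@H]2O` has not yet been measured in this assay. It differs from compound 1 by 3-nitrophenyl in place of 4-aminophenyl on an aromatic nitrogen. Among the measured compounds shown here, no measured pair shows what such a swap does, so the step from compound 1 to compound 3 cannot be read off the data. Compound 1 sits near the bottom of the scale, and there is no shown step pointing to a large rise, so the step of a number 5 percentage points higher from compound 1 to compound 3 (within the scatter) is expected to stay within the scatter. Compound 3 is expected to give about 8%, with a range from 0% to 25%.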

Compound 3, a percentage reported as inhibition, at one concentration (the size of the read-out at that concentration, not a potency): 8%
The estimate for compound 3 equals the measured number at the digits printed; low and high end bracket the measured number.
By their numbers in this assay, from the lowest: compounds 1 and 3 (each within the scatter of the next); then compound 2.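

In this assay, 3-nitrophenyl in place of 4-aminophenyl on an aromatic nitrogen of the five-membered ring gives a number 5 percentage points higher from compound 1 to compound 3 (within the scatter). At this position, then, exchanging these two substituted phenyl groups, even though the entering group has more heavy atoms and no hydrogen-bond donor, does not separate the two compounds on this read-out. Nothing measured here gives a reason for this result.

The compounds shown leave open how the change of substituent and the change of its place on the phenyl ring each count, which 3-aminophenyl or 4-nitrophenyl would separate. They also leave open whether a plain phenyl, a benzyl or a carboxylic acid on the phenyl ring at this nitrogen, or a longer chain leading to the ring, would read any differently.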